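This account rests on a few compounds, and the source may have more. Where it says the series, first, only, none or still open, it means among the compounds named here.

Working notes on the series. Two compounds carry the shared core with differing aryl groups on the saturated ring carbon: compound 1 `Cc1ccc(C(=O)C2=C(O)C(=O)N(CC(C)O)C2c2ccc(C(C)(C)C)cc2)cc1` and compound 2 `Cc1ccc(C(=O)C2=C(O)C(=O)N(CC(C)O)C2c2ccc(C(F)(F)F)cc2)cc1`. In an assay on isolated protein for inhibition of annexin A2/S100-A10 (Homo sapiens), with a stated time of 5 min, tested at 50 uM (on this read-out lower numbers stand for less inhibition and higher numbers for more inhibition at the one concentration tested (going by the name of the read-out)), compound 1 gives 123%, while compound 2 gives 102%. For the measured compounds named here, the one measured step, a number 21 percentage points lower from compound 1 to compound 2 (beyond the scatter), covers the exchange of the group itself and not its position on the aromatic ring. Among the two numbers recorded, compound 2 stands lowest, with compound 1 the nearer and higher of the pair.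

Compound 3 `Cc1ccc(C(=O)C2=C(O)C(=O)N(CC(C)O)C2c2cccc(C(F)(F)F)c2)cc1` is not yet measured. It differs from compound 2 in one place: 3-(trifluoromethyl)phenyl in place of 4-(trifluoromethyl)phenyl on a saturated ring carbon. Going by the values given here, no measured step moves a trifluoromethyl group around an aromatic ring, so the recorded step from compound 1 to compound 2 bears on this only loosely, as a sign that changes at this aryl group can shift the read-out by a modest amount. Among the compounds with values here, with no direct precedent, the step from compound 2 to compound 3 is expected to be a number 2 percentage points lower from compound 2 to compound 3 (within the scatter), that is, none beyond the scatter in either direction. Compound 3 is therefore estimated at 100%, within 75% to 125%.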

Compound 3, a percentage reported as inhibition, at one concentration (the size of the read-out at that concentration, not a potency): 110%
For compound 3 the middle estimate is 10 percentage points below the measured one; the measured number falls inside the stated range.
By their numbers in this assay, from the lowest: compounds 2 and 3 (each within the scatter of the next); then compound 1.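

In this assay, 3-(trifluoromethyl)phenyl in place of 4-(trifluoromethyl)phenyl on the saturated ring carbon gives a number 8 percentage points higher from compound 2 to compound 3 (within the scatter), so the two placements of the trifluoromethyl group cannot be told apart on this read-out. The exchange of 4-(tert-butyl)phenyl for 3-(trifluoromethyl)phenyl gives a number 13 percentage points lower from compound 1 to compound 3 (beyond the scatter), so compound 1 stands apart, beyond the scatter, from both trifluoromethyl compounds, whichever of the two placements is present. Nothing available on these compounds accounts for either step.

Still open, on these data alone, is whether the number stays level when the tert-butyl group makes the same move, as 3-(tert-butyl)phenyl, and whether it also stays level, as it does with trifluoromethyl, for an aryl group carrying an amine or a carboxylic acid at these placements. Because this assay reports a single concentration, it also leaves open whether compound 2 and compound 3 would separate in potency, or whether either would separate from compound 1 by the same margin, once a full concentration series is considered.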